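Swapping the aryl ether of a furan-bearing aminoquinoline

The source may report more compounds than this note shows. Statements on the series, on what has been measured and on what is new or still open speak of the compounds shown alone.

Compound 1 `COc1cccc(Oc2ccc3c(NCCCNCc4ccco4)ccnc3c2)c1` — in an ADME assay for permeability, using PAMPA, with a stated time of 30 min, at pH 7.4 (on this read-out lower numbers stand for lower permeability and higher numbers for higher permeability), compound 1 gives 317 10^-6 cm/s
Compound 2 `CN(C)c1cccc(Oc2ccc3c(NCCCNCc4ccco4)ccnc3c2)c1` — in this assay compound 2 gives 317 10^-6 cm/s
Compound 3 `COc1ccc(F)cc1CNCCCNc1ccnc2cc(Oc3cccc(N(C)C)c3)ccc12` — in this assay compound 3 gives 317 10^-6 cm/s

Compound 2 stands level with compound 1 and compound 3 in this assay: the step of no change at the digits printed from compound 1 to compound 2 (within the scatter) and the step of no change at the digits printed from compound 2 to compound 3 (within the scatter) both sit within the scatter, so none of the three can be called more or less permeable than another.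

Compound 4 `COc1ccccc1Oc1ccc2c(NCCCNCc3ccco3)ccnc2c1` differs from compound 2 in one place: 2-methoxyphenyl in place of 3-(dimethylamino)phenyl on an oxygen on an aromatic ring. Within the data shown here, the step that bears most on this is the one from compound 1 to compound 2, which exchanged methoxy for dimethylamino on an aromatic carbon and read no change at the digits printed from compound 1 to compound 2 (within the scatter). The further step no change at the digits printed from compound 2 to compound 3 (within the scatter), changing a group elsewhere in the molecule, likewise moved nothing. With both changes at or near the aryl ether leaving the read-out flat, a step beyond the scatter is not expected for compound 4; the estimate is no change at the digits printed from compound 2 to compound 4 (within the scatter).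

Compound 4 is therefore expected at 317 10^-6 cm/s, within a range of 160 10^-6 cm/s to 630 10^-6 cm/s.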

Compound 4, apparent permeability: 317 10^-6 cm/s
Estimate against measurement, compound 4: no gap at the digits printed; low and high end bracket the measured number.
By their numbers in this assay, from the lowest: compounds 1, 2, 3 and 4 (each within the scatter of the next).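

In this assay the reading no change at the digits printed from compound 2 to compound 4 (within the scatter) shows that the whole group on the oxygen on an aromatic ring can pass from 3-(dimethylamino)phenyl to 2-methoxyphenyl and still stay within the scatter, whereas the earlier step at this site changed only the substituent. Among these compounds, the reading no change at the digits printed from compound 1 to compound 4 (within the scatter) adds the first comparison in which the methoxy group stays while the name changes from 3-methoxyphenyl to 2-methoxyphenyl, and this exchange also stays within the scatter. Nothing measured here bears on why these readings stay level.

The compounds shown leave open whether a carboxylic acid or a primary amine on this aryl ring would read differently. With all four compounds level, they also leave open which part of the structure this read-out responds to, and whether a longer chain would shift it.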